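Cytotoxicity of Three Amides: From Aryl to Methyl

A few compounds are considered here, and "the series" means these few. Any claim that something is new, unique, unknown or untested is made for them only; others in the source may bear on it.

compound 1 `O=C(Nc1ccc(Br)cc1)c1c(NO)cc(-c2ccccc2)oc1=O` — > 20000 nM
compound 2 `COc1ccc(-c2cc(NO)c(C(=O)Nc3ccc(C)cc3)c(=O)o2)cc1` — > 20000 nM

In an ADME assay on Huh-7 cells (Homo sapiens) for cytotoxicity, read by a luciferase reporter and WST assay, with a stated time of 3 days (a higher number here means that more compound is tolerated, a lower number that less compound is tolerated), compound 1 gives > 20000 nM, which is a limit of the assay and not a number. Compound 2 likewise reaches only a limit, > 20000 nM. For the measured compounds named here, both values thus sit at the limit of > 20000 nM in this assay, at which 2 of the 2 values shown sit, so compound 1 cannot be placed higher or lower than compound 2 on what is known; it stands at the limit together with the only other measured compound.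

Compound 3 `CNC(=O)c1c(NO)cc(-c2ccccc2)oc1=O` has not yet been measured. It differs from compound 1 in one place: methyl in place of 4-bromophenyl on an amide-type nitrogen. Going by the values given here, no step between measured compounds is available, and two limits give no direction to read from. The expected step is a step that the limit leaves unreadable from compound 1 to compound 3, none beyond the scatter. Compound 3 is therefore estimated at 30000 nM, within 15000 nM to 100000 nM, most likely again as a limit.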

Compound 3, half-maximal cytotoxic concentration: > 20000 nM
Compound 3: only a limit was reported; the forecaster's own chance of this, stated with the estimate: 85%; the middle value does not contradict the limit.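

In this assay compound 3 gives > 20000 nM, which is a limit of the assay and not a number. For the compounds shown here, no step from compound 1 to compound 3 can be read: the limit of > 20000 nM in this assay, at which 3 of the 3 values shown sit. The compounds shown leave open what concentration of any of them would prove cytotoxic, and whether methyl in place of 4-bromophenyl makes any difference.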